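This account rests on a few compounds, and the source may have more. Where it says the series, first, only, none or still open, it means among the compounds named here.

Compound 1, `C[Se]c1nc(N)c2ccccc2n1`, was tested in a functional assay on HT-29 cells (Homo sapiens) for cytotoxicity, read by MTT assay, with a stated time of 72 h; on this read-out higher numbers stand for lower toxicity in this test and lower numbers for higher toxicity in this test. In this assay compound 1 gives only a limit, > 100000 nM, so its place on the scale is not a fixed number. Compound 2, `Nc1nc([SeH])nc2ccccc12`, differs from compound 1 by a hydrogen in place of a methyl on a selenium. In this assay compound 2 likewise gives only a limit, > 100000 nM. Among the compounds with values here, the step that the two limits leave unreadable from compound 1 to compound 2 is therefore one whose size cannot be read, and the only evidence is the limit of > 100000 nM in this assay, at which 2 of the 2 values shown sit. Compound 3, `C[Se]c1nc([Se]C)c2ccccc2n1`, has not yet been measured; compared with compound 1 it carries a group of 2 heavy atoms (1 carbon, 1 selenium; no ring) in place of one nitrogen atom, on an aromatic carbon. Within the data shown here, no measured step shows how this change acts, and neither compound measured so far produced a number in this assay. Compound 3 is therefore expected to sit near compound 1, with an expected step that the limit leaves unreadable from compound 1 to compound 3. The estimate for compound 3 in this assay is 150000 nM, ranging from 50000 nM to 500000 nM, most likely as another limit.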

Compound 3, concentration lethal to 50% of the cells: 76800 nM
Compound 3: the middle estimate sits 2.0-fold (0.29 log units) above what was measured; the range from low to high includes it.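

In this assay, placing a group of 2 heavy atoms (1 carbon, 1 selenium) on this aromatic carbon in place of the amino group gives an at least 1.3-fold lower number from compound 1 to compound 3 (0.11 log units; that floor lies within the scatter). This shows that a change at this position can bring a compound within the range where the test gives a number, although the size of the step cannot be told apart from ordinary scatter. Compound 3 alone gives a number, so it offers the only fixed point on the scale: the limit of > 100000 nM in this assay, at which 2 of the 3 values shown sit.

The compounds shown do not separate the loss of the amino group from the arrival of the selenium-bearing group. They also leave open how a longer chain on the selenium, or a methoxy group or a chlorine atom on this carbon, would read.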